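The source may hold more compounds than are shown below. What is called first, only, known or untested is meant among the compounds shown, and "the series" means these compounds.

Measured compounds in an assay on K562 cells for displacement of a labelled ligand from Equilibrative nucleoside transporter 1 (Homo sapiens); a lower number here means a stronger inhibitor, a higher number a weaker inhibitor:
compound 1 `OC[C@H]1O[C@@H](n2cnc3c(SCc4ccccc4Br)ncnc32)[C@H](O)[C@@H]1O` — 134 nM
compound 2 `OC[C@H]1O[C@@H](n2cnc3c(SCc4ccc(Br)cc4)ncnc32)[C@H](O)[C@@H]1O` — 9.98 nM
compound 3 `OC[C@H]1O[C@@H](n2cnc3c(SCc4ccccc4Cl)ncnc32)[C@H](O)[C@@H]1O` — 99.5 nM

Compound 1 gives the highest number of the three; compound 3 sits within the scatter of it, compound 2 well below. Compound 4 `OC[C@H]1O[C@@H](n2cnc3c(SCc4cccc(Cl)c4)ncnc32)[C@H](O)[C@@H]1O` is not yet measured. It differs from compound 1 by 3-chlorophenyl in place of 2-bromophenyl on a saturated chain carbon bound to a sulfur. Going by the values given here, two measured steps bear on this. Moving the halogen out of the 2-position gave a 13-fold lower number from compound 1 to compound 2 (1.13 log units; beyond the scatter), whereas the halogen swap gave a 1.3-fold lower number from compound 1 to compound 3 (0.13 log units; within the scatter), so the halogen identity matters little here and the ring position carries the effect. Among the compounds with values here, the 3-chloro substituent has no direct precedent, so compound 4 is expected to fall between the 2-substituted pair and compound 2, a step of a 3.8-fold lower number from compound 1 to compound 4 (0.58 log units; beyond the scatter) in this assay. Compound 4 is estimated at 35 nM, range 8 nM to 150 nM.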

Compound 4, inhibition constant: 16 nM
Beside the measured number, compound 4's estimate is 2.2-fold (0.34 log units) above it; the measured number falls inside the stated range.
By their numbers in this assay, from the lowest: compounds 2 and 4 (each within the scatter of the next); then compounds 3 and 1 (each within the scatter of the next).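

In this assay, 3-chlorophenyl on a saturated chain carbon bound to a sulfur beats both 2-substituted compounds: an 8.4-fold lower number from compound 1 to compound 4 (0.92 log units; beyond the scatter) and a 6.2-fold lower number from compound 3 to compound 4 (0.79 log units; beyond the scatter). The second step keeps chlorine and changes only the ring position, so the position effect no longer rests on a pair that also changes the halogen. Against 4-bromophenyl, a 1.6-fold higher number from compound 2 to compound 4 (0.20 log units; within the scatter), leaving those two groups unresolved.

As far as these compounds go, whether an amine, a carboxylic acid or a longer chain on this ring would keep the number near that of compound 4 remains open. No evidence on hand explains these steps.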